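Replacing Chloro with Piperidin-4-yl on the Pendant Phenyl

The source may report more compounds than this note shows. Statements on the series, on what has been measured and on what is new or still open speak of the compounds shown alone.

Compound 2 `COc1cccc(-c2nc3c(-c4ccc(Cl)cc4)n[nH]c3c(=O)n2NC(=O)c2ccncc2)c1` stands highest of the two numbers in a functional assay on A549 cells (Homo sapiens) for cytotoxicity, read by sulforhodamine B assay, with a stated time of 2 days, tested at 100 uM (on this read-out lower numbers stand for less inhibition and higher numbers for more inhibition at the one concentration tested (going by the name of the read-out)), giving 46%. Compound 1 `CCCc1n[nH]c2c(=O)n(NC(=O)c3ccncc3)c(-c3cccc(OC)c3)nc12` gives 11.2%; the step of a number 34.8 percentage points higher from compound 1 to compound 2 (beyond the scatter) shows how strongly one alteration on the shared core can shift this read-out. Compound 3 `COc1cccc(-c2nc3c(-c4ccc(C5CCNCC5)cc4)n[nH]c3c(=O)n2NC(=O)c2ccncc2)c1` differs from compound 2 by piperidin-4-yl in place of chloro on an aromatic carbon. Within the data shown here, no measured step tests this same change, so the one known step only indicates that this part of the molecule can matter, without giving a direction. For compound 3 a step of about a number 6 percentage points lower from compound 2 to compound 3 (within the scatter) is expected, with its value estimated at 40%, within 15% to 65%.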

Compound 3, a percentage reported as inhibition, at one concentration (the size of the read-out at that concentration, not a potency): 32.4%
Estimate against measurement, compound 3: 7.6 percentage points above; low and high end bracket the measured number.
By their numbers in this assay, from the lowest: compound 1; then compound 3; then compound 2.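

Piperidin-4-yl in place of chloro brings a number 13.6 percentage points lower from compound 2 to compound 3 (beyond the scatter) in this assay, so the read-out also responds to what sits on the phenyl ring, not only to replacing propyl with a substituted phenyl. The 4-(piperidin-4-yl)phenyl group still gives a number 21.2 percentage points higher from compound 1 to compound 3 (beyond the scatter), so both phenyl-bearing groups shown stand above propyl. No measurement shown here accounts for either step. Going by these compounds, it remains open whether the ring or its nitrogen sets the number: a cyclohexyl or an aminomethyl group in the same place could separate the two.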